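The source may report more compounds than this note shows. Statements on the series, on what has been measured and on what is new or still open speak of the compounds shown alone.

Three members of this series have been measured. Compound 1 `N=C(N)NCCC[C@H](NC(=O)CN(c1ncnc2c1ncn2C1CCCCO1)C1CC1)C(=O)OCc1ccccc1` gives 38.2% in a functional assay on the whole organism (Tail, strain ICR) with Mus musculus as the target, in the tail flick test, with a stated time of 120 min, at a dose of 25 umol/kg by the oral route; on this read-out lower numbers stand for a weaker effect and higher numbers for a stronger effect at the one dose given. Compound 3 `CSCC[C@H](NC(=O)CN(c1ncnc2c1ncn2C1CCCCO1)C1CC1)C(=O)OCc1ccccc1` gives 28.7% in this assay, and the change from compound 1 to compound 3 a number 9.5 percentage points lower from compound 1 to compound 3 (within the scatter), so these two stand together. Compound 2 `O=C(CN(c1nc(Cl)nc2[nH]cnc12)C1CC1)N[C@@H](CC(=O)OCc1ccccc1)C(=O)OCc1ccccc1` gives 12.1% in this assay and holds the lowest of the three numbers, with compound 3 the nearest of the others and compound 1 the furthest, both beyond the scatter.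

The step under consideration leads from compound 2 to compound 4 `C[C@@H](O)[C@H](NC(=O)CN(c1nc(Cl)nc2[nH]cnc12)C1CC1)C(=O)OCc1ccccc1`, which is not yet measured. The change is 1-hydroxyethyl in place of (benzyloxycarbonyl)methyl on a saturated chain carbon bound to an amide-type nitrogen and a carbonyl carbon.

Going by the values given here, no measured pair shows this exact change; the only step recorded at all, that from compound 1 to compound 3, also exchanges the side group on a chain carbon of the amino-acid part, and it stayed within the scatter. On that basis no step beyond the scatter is expected in this assay, though a single within-scatter precedent is a weak guide. Compound 4 is accordingly expected to give about 15%, within a range from 2% to 30%, which would mean an expected step of a number 2.9 percentage points higher from compound 2 to compound 4 (within the scatter).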

Compound 4, a percentage reported as activity, at one dose (the size of the read-out at that dose, not a potency): 30.7%
For compound 4 the middle estimate is 15.7 percentage points below the measured one; measured number above the stated range.
By their numbers in this assay, from the lowest: compound 2; then compounds 3, 4 and 1 (each within the scatter of the next).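

In this assay the exchange of (benzyloxycarbonyl)methyl for 1-hydroxyethyl gives a number 18.6 percentage points higher from compound 2 to compound 4 (beyond the scatter) and so shows that the group on this saturated chain carbon can move the read-out beyond the scatter, which a number 9.5 percentage points lower from compound 1 to compound 3 (within the scatter) did not show. It also shows that, on the core of compound 2, this place does not need a group with an aromatic ring for the effect seen at this dose, since 1-hydroxyethyl, with no ring, stands with the higher number. The change alters the size of the group, removes its ring and ester, and brings in a hydroxyl hydrogen-bond donor and a defined stereocentre all at once, and nothing available here separates these changes or explains the step.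

The compounds shown leave open whether a hydroxymethyl or a plain methyl group at this place would stand with compound 4 or with compound 2, and what a free carboxylic acid in place of the benzyl ester of the side group would do. Also open, on these data alone, is whether the same exchange on the core of compound 1 would give a step of similar size.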